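Replacing 3-methylphenyl with 2-cyanophenyl in compound 3

This account rests on a few compounds, and the source may have more. Where it says the series, first, only, none or still open, it means among the compounds named here.

Measured in a toxicity assay on MT4 cells (Homo sapiens) for cytotoxicity, read by MTT assay; a lower number here means that less compound is tolerated, a higher number that more compound is tolerated:
compound 1 `Cc1cc(-c2ccccc2F)cc(C)c1Oc1cc(N)nc(Nc2ccc(C#N)cc2)n1` gives 29300 nM
compound 2 `Cc1cc(-c2cccc(Cl)c2)cc(C)c1Oc1cc(N)nc(Nc2ccc(C#N)cc2)n1` gives 22300 nM
compound 3 `Cc1cccc(-c2cc(C)c(Oc3cc(N)nc(Nc4ccc(C#N)cc4)n3)c(C)c2)c1` gives 27600 nM

Compound 3, at 27600 nM, lies within the scatter of both other compounds, with a 1.1-fold lower number from compound 1 to compound 3 (0.03 log units; within the scatter) and a 1.2-fold higher number from compound 2 to compound 3 (0.09 log units; within the scatter). Compound 4 `Cc1cc(-c2ccccc2C#N)cc(C)c1Oc1cc(N)nc(Nc2ccc(C#N)cc2)n1` carries 2-cyanophenyl in place of 3-methylphenyl on an aromatic carbon. For the measured compounds named here, all the measured steps exchange the group at this place, and a 1.3-fold lower number from compound 1 to compound 2 (0.12 log units; within the scatter) is equally small. Going by the values given here, no measured compound carries 2-cyanophenyl, so this rests on related groups only. No change beyond the scatter is therefore expected, and the estimate is a 1.2-fold lower number from compound 3 to compound 4 (0.06 log units; within the scatter). For compound 4 the expected value is 24000 nM, with an estimated range from 11000 nM to 48000 nM.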

Compound 4, half-maximal cytotoxic concentration: 25400 nM
For compound 4 the middle estimate is 1.1-fold (0.02 log units) below the measured one, within the range that was stated.
By their numbers in this assay, from the lowest: compounds 2, 4, 3 and 1 (each within the scatter of the next).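

In this assay, 2-cyanophenyl brings a nitrile and a hydrogen-bond acceptor to this position, yet all three steps stay within the scatter (a 1.1-fold lower number from compound 3 to compound 4 (0.04 log units; within the scatter); a 1.1-fold higher number from compound 2 to compound 4 (0.06 log units; within the scatter); a 1.2-fold lower number from compound 1 to compound 4 (0.06 log units; within the scatter)). The last of these shows that cyano in place of fluoro on the same ring also leaves the number within the scatter, so the four aryl groups shown cannot be told apart in this measurement. No supporting evidence is available to explain this flat result.

Going by these compounds, whether an amine or a carboxylic acid on this ring would also stay within the scatter remains open. The same holds for a longer chain in place of the ring.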